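Imidazolyl thioethers: lactone to benzyl at the sulfur-bound carbon

A few compounds are considered here, and "the series" means these few. Any claim that something is new, unique, unknown or untested is made for them only; others in the source may bear on it.

Two measured compounds anchor the series. Compound 1 `Cc1ccc(-c2nc(SC[C@H]3C[C@@](C)(O)CC(=O)O3)[nH]c2-c2ccc(C)cc2)cc1.Cc1ccc(-c2nc(SC[C@H]3C[C@](C)(O)CC(=O)O3)[nH]c2-c2ccc(C)cc2)cc1` gives 170 nM in an assay on microsomes from liver for inhibition of sterol O-acyltransferase 1 (Rattus norvegicus); on this read-out lower numbers stand for stronger inhibition and higher numbers for weaker inhibition. Compound 2 `O=C1CC(O)CC(CSc2nc(-c3ccccc3)c(-c3ccccc3)[nH]2)O1` gives 910 nM in this assay and thus stands with the highest of the two numbers shown; its nearest neighbour is compound 1, whose lower number lies beyond the scatter. Among the measured compounds shown here, no step between compounds differing in a single place has been measured, so the pair shows only that the two differ.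

Compound 3 `c1ccc(CSc2nc(-c3ccccc3)c(-c3ccccc3)[nH]2)cc1` is not yet measured. It differs from compound 2 as follows: a group of 6 heavy atoms (6 carbon; one six-membered aromatic ring of carbon only) in place of a group of 8 heavy atoms (5 carbon, 3 oxygen; one six-membered non-aromatic ring with 1 hetero atom), on a saturated chain carbon bound to a sulfur. For the measured compounds named here, no measured pair shows what such a swap does here. The expectation is a weakening step, from compound 2 to compound 3, of a 3.3-fold higher number from compound 2 to compound 3 (0.52 log units; beyond the scatter) in this assay, larger than the scatter but not certain in direction. For compound 3 the estimate in this assay is 3000 nM, with a range from 800 nM to 12000 nM.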

Compound 3, half-maximal inhibitory concentration: 290 nM
Beside the measured number, compound 3's estimate is 10-fold (1.01 log units) above it; measured number outside the range, below it.
By their numbers in this assay, from the lowest: compounds 1 and 3 (each within the scatter of the next); then compound 2.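

On a saturated chain carbon bound to a sulfur, phenyl in place of the group of 8 heavy atoms with its six-membered non-aromatic ring gives, in this assay, a 3.1-fold lower number from compound 2 to compound 3 (0.50 log units; beyond the scatter). This pair therefore shows that the 1 hydrogen-bond donor and 3 hydrogen-bond acceptors of the departing group are not required at this position for inhibition at the level of compound 3. Nothing available here explains why the number falls with this swap.

As far as these compounds go, whether an amine, a carboxylic acid or a longer chain at the same position would give a lower or a higher number remains open. From the compounds shown here alone, the step also rests on one pair, so whether the same swap behaves alike on the core of compound 1 is unknown.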